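A few compounds are considered here, and "the series" means these few. Any claim that something is new, unique, unknown or untested is made for them only; others in the source may bear on it.

Going by the values given here, compound 1 `COc1c(NS(=O)(=O)c2ccc(F)cc2)cc(-c2ccc3nc(NC4CC4)sc3n2)cc1C(N)=O` is the only compound here with a measured number: in a functional assay on A549 cells (Homo sapiens) for antiproliferative activity, read by MTT assay, with a stated time of 72 h (a higher number here means a weaker inhibitor, a lower number a stronger inhibitor), compound 1 gives 30300 nM, a weak result. Compound 2 `COc1c(NS(=O)(=O)C2CC2)cc(-c2ccc3nc(NC(C)=O)nn3c2)cc1C(N)=O` has no number in this assay; its entry reads "not determined" (no result reported). Compound 3 `COc1c(NS(=O)(=O)c2ccc(F)cc2)cc(-c2ccc3nc(NC(=O)C4CC4)sc3n2)cc1C(N)=O` differs from compound 1 in a single place: cyclopropylcarbonyl in place of cyclopropyl on a nitrogen on an aromatic ring. Among the compounds with values here, no measured pair shows what this change does, so the expectation rests on compound 1 alone. A modest gain in potency is expected, a 2.0-fold lower number from compound 1 to compound 3 (0.31 log units; beyond the scatter), though the step may well fall within the scatter. Compound 3 is estimated at 15000 nM, with a range from 3000 nM to 60000 nM.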

Compound 3, half-maximal inhibitory concentration: 8050 nM
Beside the measured number, compound 3's estimate is 1.9-fold (0.27 log units) above it; the range from low to high includes it.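

Replacing the cyclopropylamino group with (cyclopropylcarbonyl)amino gives a 3.8-fold lower number from compound 1 to compound 3 (0.58 log units; beyond the scatter) in this assay. This shows that the read-out responds to a change at this nitrogen and that adding a carbonyl here does not cost potency, although the gain is modest. No measurement shown accounts for the gain. The compounds shown leave open whether other acyl groups on this nitrogen, such as benzoyl or a longer chain like pentanoyl, would go further. A urea in the same place is equally untested here.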